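The compounds below may be only part of what the source reports. "The series", "measured", "known", "first", "only" and "open" are said of these compounds alone.

Working notes on the series.

Compound 1 `c1ccc2c(-c3cn4ccnc4c(-c4ccc5ncn(C6CCCCC6)c5c4)n3)cccc2c1` is the reference point. In a functional assay on LOX IMVI cells (Homo sapiens) for inhibition, read by sulforhodamine B assay, with a stated time of 48 h, tested at 10 uM (on this read-out higher numbers stand for more inhibition at the one concentration tested (going by the name of the read-out) and lower numbers for less inhibition), compound 1 gives 7.43%. Compound 2 `c1ccc(Cn2cnc3ccc(-c4nc(-c5cccc6ccccc56)cn5ccnc45)cc32)cc1` differs from it in one place (benzyl in place of cyclohexyl on an aromatic nitrogen), and in this assay compound 2 gives 16.5%; the step of a number 9.1 percentage points higher from compound 1 to compound 2 (within the scatter) is small, so the two read-outs are not separated here.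

Compound 3 `c1cn2cc(-c3ccc4c(c3)ncn4C3CCCCC3)nc(-c3ccc4ncn(C5CCCCC5)c4c3)c2n1` carries a different core; how the core of compound 3 differs from the core of compound 1 is not broken down here. In this assay compound 3 gives 25.9%. Against compound 1 this is a higher number and the gap lies beyond the scatter; against compound 2 the gap lies within the scatter, so the two numbers of compound 2 and compound 3 are to be read as indistinguishable.

Compound 4 `c1ccc(Cn2cnc3ccc(-c4nc(-c5ccc6c(c5)ncn6C5CCCCC5)cn5ccnc45)cc32)cc1` is not yet measured. It stands to compound 3 as compound 2 stands to compound 1: the change benzyl in place of cyclohexyl on an aromatic nitrogen is the same change, made at the same kind of place on the core of compound 3. Going by the values given here, the only guide to its size is the measured pair, where the step of a number 9.1 percentage points higher from compound 1 to compound 2 (within the scatter) stayed within the scatter. On that basis the step from compound 3 to compound 4 is expected to be of similar size, a number 6.1 percentage points higher from compound 3 to compound 4 (within the scatter), and again not clearly resolved from zero. For compound 4 the estimated read-out in this assay is therefore 32%, with an expected range from 18% to 46%.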

Compound 4, a percentage reported as inhibition, at one concentration (the size of the read-out at that concentration, not a potency): -87%
For compound 4 the middle estimate is 119 percentage points above the measured one; the whole stated range lies above it.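

In this assay, the change benzyl in place of cyclohexyl on an aromatic nitrogen is large on the core of compound 3, with a number 112.9 percentage points lower from compound 3 to compound 4 (beyond the scatter). Going by these compounds alone, its size therefore does not carry over from the core of compound 1 to the core of compound 3 in this assay: the same change on two cores in this assay, a number 9.1 percentage points higher (within the scatter) from compound 1 to compound 2 and a number 112.9 percentage points lower (beyond the scatter) from compound 3 to compound 4, 122 percentage points apart, beyond the scatter of two such steps This rests on only two matched pairs, so it shows that the effect of the change depends on the core in these two cases, but it does not show which feature of the core is responsible, how the change would behave on any further core, or what lies behind the negative number of compound 4, -87%.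

The compounds shown leave open whether the number in this assay would be higher, lower or level with groups other than cyclohexyl and benzyl on the aromatic nitrogen, such as a longer chain or a chain ending in an amine, on either core. They also leave open whether the large step seen with compound 4 would recur on other cell lines or at other concentrations, since the read-out here comes from one cell line at one concentration.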